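Urea aryl swap: chloro for trifluoromethyl on the terminal phenyl

A few compounds are considered here, and "the series" means these few. Any claim that something is new, unique, unknown or untested is made for them only; others in the source may bear on it.

Two compounds of this urea series have numbers in a functional assay on SNB-75 cells (Homo sapiens) for inhibition, read by sulforhodamine B assay, with a stated time of 48 h, tested at 10 uM; on this read-out lower numbers stand for a stronger effect and higher numbers for a weaker effect at the one concentration tested. Compound 1 `O=C(Nc1cccc(-n2cc(-c3ccncc3)c(-c3cc(O)cc(Cl)c3)n2)c1)Nc1ccc(Cl)c(Cl)c1` gives 4.08% in this assay. Going by the values given here, compound 2 `COc1cc(Cl)cc(-c2nn(-c3cccc(NC(=O)Nc4ccc(Cl)c(C(F)(F)F)c4)c3)cc2-c2ccncc2)c1` gives 14.5% in this assay, the higher of the two numbers and beyond the scatter from compound 1; no single-site step between them is known, since compound 1 and compound 2 differ at more than one place, so only the two values themselves can be set side by side.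

Compound 3 `COc1cc(Cl)cc(-c2nn(-c3cccc(NC(=O)Nc4ccc(Cl)c(Cl)c4)c3)cc2-c2ccncc2)c1` is not yet measured in this assay. It keeps the methoxy-bearing core of compound 2 and differs from it only at the terminal urea phenyl: chloro in place of trifluoromethyl on an aromatic carbon, read one bond further out as 4-chloro-3-(trifluoromethyl)phenyl to 3,4-dichlorophenyl. Compound 1 carries the same 3,4-dichlorophenyl urea and gives the lower number.

For compound 3 a step of a number 5.5 percentage points lower from compound 2 to compound 3 (within the scatter) is expected, downward, of modest size and not far beyond the scatter. Compound 3 is estimated at 9% in this assay, with a range from -2% to 22%.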

Compound 3, a percentage reported as activity, at one concentration (the size of the read-out at that concentration, not a potency): 16.2%
Compound 3: middle estimate off by 7.2 percentage points, on the low side, and the stated range covers the measured number.
By their numbers in this assay, from the lowest: compound 1; then compounds 2 and 3 (each within the scatter of the next).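

In this assay the change from trifluoromethyl to chloro on the terminal urea phenyl, on an aromatic carbon ortho to a chloro group, gives a number 1.7 percentage points higher from compound 2 to compound 3 (within the scatter) on the methoxy-bearing core, so the two groups are not told apart at this position on this read-out. With the 3,4-dichlorophenyl urea held fixed, methyl in place of hydrogen on the oxygen on the aromatic ring gives a number 12.1 percentage points higher from compound 1 to compound 3 (beyond the scatter), which places the one single-site difference beyond the scatter at that oxygen and not at the urea phenyl. No measurement at hand accounts for either step.

Still open is whether the step at the oxygen keeps its size when the urea carries 4-chloro-3-(trifluoromethyl)phenyl instead of 3,4-dichlorophenyl, since only one such pair is shown. Also open, from the compounds shown here alone, is how the terminal phenyl position reads with a group of another kind, such as a nitrile or an amine, and how the oxygen reads with a longer chain such as ethyl in place of methyl.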